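Notes on the step from compound 1 to compound 3

The compounds below may be only part of what the source reports. "The series", "measured", "known", "first", "only" and "open" are said of these compounds alone.

Compound 1 `COc1ccc(NC(=O)NCCNS(=O)(=O)c2ccc(-c3ccccc3OCc3ccccc3)s2)cc1` reads > 20000 nM in a functional assay on RS4-11 cells (Homo sapiens) for inhibition, read by CCK-8 assay, with a stated time of 48 h (a lower number here means a stronger inhibitor, a higher number a weaker inhibitor), and this is a limit of the assay, not a number. The record for compound 1 is therefore (the limit of > 20000 nM in this assay, at which 1 of the 2 values shown sits).

Compound 2 `O=C(NCCNS(=O)(=O)c1ccc(-c2ccccc2Oc2ccc(O)c(O)c2)s1)Nc1cc(Cl)cc(Cl)c1` gives a measured number in this assay, 4500 nM. Among the compounds with values here, it is the only numerical reading available so far.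

Compound 3 `O=[N+]([O-])c1cccc(NC(=S)NCCNS(=O)(=O)c2ccc(-c3ccccc3OCc3ccccc3)s2)c1` keeps the core of compound 1 and changes one group on an amine nitrogen: a group of 12 heavy atoms (7 carbon, 2 nitrogen, 2 oxygen, 1 sulfur; one six-membered aromatic ring of carbon only) in place of a group of 11 heavy atoms (8 carbon, 1 nitrogen, 2 oxygen; one six-membered aromatic ring of carbon only), on an amine nitrogen. Within the data shown here, the entering group has no common name, and no measured pair isolates this change.

Among the measured compounds shown here, with no such pair, the expectation in this assay is only a modest shift toward stronger inhibition, and a second reading at the limit is quite possible. The expected size is an at least 1.6-fold lower number from compound 1 to compound 3 (0.22 log units; that floor lies within the scatter), and this is loose, as compound 1 provides only a limit as a starting point. Compound 2 at 4500 nM shows that a number can be obtained in this assay, so the estimate stays on the weak side of the scale.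

For compound 3 the estimated value is 12000 nM, with an expected range of 4500 nM to 25000 nM.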

Compound 3, half-maximal inhibitory concentration: 11600 nM
Beside the measured number, compound 3's estimate is 1.0-fold (0.01 log units) above it, and the stated range covers the measured number.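

In this assay compound 1 gives > 20000 nM, which is a limit and not a number. On the same core, the group of 12 heavy atoms with sulfur on the amine nitrogen brings the series to a numerical reading in compound 3, which shows that a change at this one position alone can move a compound off the limit, with the step being an at least 1.7-fold lower number from compound 1 to compound 3 (0.23 log units; that floor lies within the scatter). The printed size is only a floor that does not clear the scatter, so the step gives a direction at best and its true size stays unknown: the limit of > 20000 nM in this assay, at which 1 of the 3 values shown sits.

The entering group differs from the leaving one in both the sulfur atom and the substituents on its aromatic ring, and no compound shown separates these two parts, so neither can be credited with the step. Also open, from the compounds shown here alone, is how this position responds to other groups on the aromatic ring, such as an amine or a carboxylic acid, and to a longer chain between that ring and the amine nitrogen.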